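This account rests on a few compounds, and the source may have more. Where it says the series, first, only, none or still open, it means among the compounds named here.

In a functional assay on A549 cells (Homo sapiens) for antiproliferative activity, read by MTT assay, with a stated time of 48 h (a higher number here means a weaker inhibitor, a lower number a stronger inhibitor), three compounds have been measured so far. Compound 1 (`O=C1Nc2ccc(Nc3ccc(Cl)cc3)cc2/C1=C\C1CCCCC1`) gives 2400 nM, compound 2 (`CCCCC1(O)C(=O)Nc2ccc(Nc3ccc(C)cc3)cc21`) gives 7500 nM and compound 3 (`CCCCC1(O)C(=O)Nc2ccc(Nc3ccc(F)cc3)cc21`) gives 6500 nM. Compound 3 therefore lies within the scatter of compound 2, and its number is higher than that of compound 1.

The next compound, compound 4 (`CCCCCCC1(O)C(=O)Nc2ccc(Nc3ccc(F)cc3)cc21`), differs from compound 3 by ethyl in place of hydrogen on a saturated chain carbon, four bonds along the chain from a saturated ring carbon. Among the compounds with values here, the only measured step, a 1.2-fold lower number from compound 2 to compound 3 (0.06 log units; within the scatter), is fluoro in place of methyl on an aromatic carbon. Within the data shown here, it says nothing direct about the chain, and no measured pair changes the chain alone. Compound 1 also differs from the others in more than one place, so its value of 2400 nM tilts the expectation only slightly towards a lower number. Among the measured compounds shown here, no step clearly beyond the scatter is expected in this assay. An expected step of a 1.4-fold lower number from compound 3 to compound 4 (0.13 log units; within the scatter) is the working assumption. For compound 4 the estimate is 4800 nM, with an expected range of 2000 nM to 11000 nM.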

Compound 4, half-maximal inhibitory concentration: 12000 nM
Estimate against measurement, compound 4: 2.5-fold (0.40 log units) below; the whole stated range lies below it.
By their numbers in this assay, from the lowest: compound 1; then compounds 3, 2 and 4 (each within the scatter of the next).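

In this assay, the chain now has its first measured step: ethyl in place of hydrogen on a saturated chain carbon, four bonds along the chain from a saturated ring carbon, gives a 1.8-fold higher number from compound 3 to compound 4 (0.27 log units; within the scatter) and so stays within the scatter. The position therefore accepts 2 further carbon atoms without a step beyond the scatter, and this single step gives no sign of a lower number from extending the chain. No measurement is available that would account for this step.

Still open, from the compounds shown here alone, is whether a longer chain, a branched chain or a chain ending in an amine or a carboxylic acid would move the number beyond the scatter. Compound 1, at 2400 nM in this assay, differs from the other compounds in more than one place, so it cannot show which change separates it from them.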